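Swapping methoxy for trifluoromethoxy on the outer phenyl ring

A few compounds are considered here, and "the series" means these few. Any claim that something is new, unique, unknown or untested is made for them only; others in the source may bear on it.

The three measured compounds, all sharing one core, are:
Compound 1 `COC(=O)C1=C(C)N=C(C)/C(=C(/O)OC)C1c1cccc(N/C(=N/CCNC2CCN(c3ccccc3C)CC2)NC#N)c1`, which in an assay on SK-N-MC cells for inhibition of Neuropeptide Y receptor type 1 (Homo sapiens) (a lower number here means a stronger inhibitor, a higher number a weaker inhibitor), gives 4 nM.
Compound 2 `COC(=O)C1=C(C)N=C(C)/C(=C(/O)OC)C1c1cccc(N/C(=N/CCNC2CCN(c3ccccc3C#N)CC2)NC#N)c1`, which in this assay gives 3 nM.
Compound 3 `COC(=O)C1=C(C)N=C(C)/C(=C(/O)OC)C1c1cccc(N/C(=N/CCNC2CCN(c3ccccc3OC)CC2)NC#N)c1`, which in this assay gives 4 nM.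

Compound 3 stands level with compound 1 on the numbers shown, and these two together have the highest numbers of the three, although every gap here sits within the scatter. The steps among them are small: a 1.3-fold lower number from compound 1 to compound 2 (0.12 log units; within the scatter); no change at the digits printed from compound 1 to compound 3 (within the scatter); a 1.3-fold higher number from compound 2 to compound 3 (0.12 log units; within the scatter). So far, changing the group on that aromatic carbon between methyl, cyano and methoxy has left this assay essentially untouched.

Compound 4 `COC(=O)C1=C(C)N=C(C)/C(=C(/O)OC)C1c1cccc(N/C(=N/CCNC2CCN(c3ccccc3OC(F)(F)F)CC2)NC#N)c1` differs from compound 3 by trifluoromethyl in place of methyl on an oxygen on an aromatic ring. This change sits at the same outer part of the molecule as the earlier swaps, one bond further out. Those swaps bear on it, and since none of them moved this assay beyond the scatter, no step beyond the scatter is expected here either.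

The expected step is a 1.3-fold higher number from compound 3 to compound 4 (0.10 log units; within the scatter). Compound 4 is therefore estimated at 5 nM, within a range from 2 nM to 15 nM.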

Compound 4, half-maximal inhibitory concentration: 28 nM
The estimate for compound 4 lay 5.6-fold (0.75 log units) below the measured number; the measured number lies above the stated range.
By their numbers in this assay, from the lowest: compounds 2, 1 and 3 (each within the scatter of the next); then compound 4.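

In this assay, among these compounds, this position turns out not to be indifferent to what it carries: replacing methyl with trifluoromethyl on the oxygen gives a 7.0-fold higher number from compound 3 to compound 4 (0.85 log units; beyond the scatter) and is the first step in this set to pass the scatter. The gap also holds against the two other compounds, with a 7.0-fold higher number from compound 1 to compound 4 (0.85 log units; beyond the scatter) and a 9.3-fold higher number from compound 2 to compound 4 (0.97 log units; beyond the scatter), so the 2-(trifluoromethoxy)phenyl group stands apart from the other three outer groups, which remain within the scatter of one another. Nothing available here explains why this one change moves the number when the earlier swaps did not.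

The compounds shown leave open whether the shift is tied to the fluorine atoms themselves or would also appear with a plain ethyl or a longer alkyl chain on the same oxygen. They also leave open how a single fluorine, a chlorine or an amine on that aromatic carbon would read in this assay, and so how far the tolerance seen with methyl, cyano and methoxy extends.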